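The compounds below may be only part of what the source reports. "The series", "measured", "known", "first", "only" and "open" are said of these compounds alone.

Measured compounds:
- compound 1, `CC1CC/C(=N\Nc2ccccc2)c2nccc(=O)n21`: > 100 umol/kg
- compound 2, `CC1CC/C(=N\Nc2cccc(C(=O)O)c2)c2nccc(=O)n21`: > 100 umol/kg

In a functional assay on the whole organism for inhibition, with Rattus norvegicus as the target (a higher number here means that more compound is needed for the effect, a lower number that less compound is needed), compound 1 gives > 100 umol/kg, which is a limit of the assay rather than a number. Among the compounds with values here, compound 2 gives > 100 umol/kg, also a limit. the limit of > 100 umol/kg in this assay, at which 2 of the 2 values shown sit. The single measured change is a step that the two limits leave unreadable from compound 1 to compound 2, so its size cannot be read. Compound 3, `CCOC(=O)c1cnc2n(c1=O)C(C)CC/C2=N\Nc1ccccc1`, differs from compound 1 in one place: ethoxycarbonyl in place of hydrogen on an aromatic carbon. Within the data shown here, no measured step bears on this change, and no direction can be inferred from the two limits. Compound 3 is therefore expected to stay near the limit, with an estimated 150 umol/kg (range 40 umol/kg to 1000 umol/kg), an expected step that the limit leaves unreadable from compound 1 to compound 3.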

Compound 3, dose for 50% inhibition: > 1000 umol/kg
Compound 3 gave a limit, no number; the forecaster's own chance of this, stated with the estimate: 80%; at least 6.6-fold (0.82 log units) between middle value and limit.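

Within the data shown here, compound 1 and compound 3 each give only a limit in this assay, so no step between them can be read. The compounds shown leave open whether ethoxycarbonyl changes the dose needed at all.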